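Swapping the halogen-bearing phenyl on the five-membered ring

The source may hold more compounds than are shown below. What is called first, only, known or untested is meant among the compounds shown, and "the series" means these compounds.

Compound 1 `NS(=O)(=O)c1ccc(N2N=C(c3ccc(Oc4ccccc4)cc3)CC2c2ccccc2F)cc1`: 32000 nM
Compound 2 `NS(=O)(=O)c1ccc(N2N=C(c3ccccc3)CC2c2ccccc2F)cc1`: 21000 nM

Both were tested in an ADME assay on BHK-21 cells (Mesocricetus auratus) for cytotoxicity, read by MTT assay, with a stated time of 72 h; on this read-out lower numbers stand for higher toxicity in this test and higher numbers for lower toxicity in this test. Among the compounds with values here, compound 1 gives the highest of the two numbers, and its only neighbour is compound 2; the step of a 1.5-fold lower number from compound 1 to compound 2 (0.18 log units; within the scatter) lies within the scatter. Compound 3 `NS(=O)(=O)c1ccc(N2N=C(c3ccc(Oc4ccccc4)cc3)CC2c2cccc(Cl)c2)cc1` has not yet been measured. It differs from compound 1 in one place: 3-chlorophenyl in place of 2-fluorophenyl on a saturated ring carbon. Within the data shown here, the single measured step concerns a different part of the molecule, so no measured step bears on this change. With nothing pointing either way, the step of a 1.1-fold lower number from compound 1 to compound 3 (0.03 log units; within the scatter) is expected to stay within the scatter. Compound 3 is expected to give about 30000 nM, with a range from 12000 nM to 75000 nM.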

Compound 3, half-maximal cytotoxic concentration: 9000 nM
Compound 3: middle estimate off by 3.3-fold (0.52 log units), on the high side, and the stated range ends above it.
By their numbers in this assay, from the lowest: compound 3; then compounds 2 and 1 (each within the scatter of the next).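

Replacing 2-fluorophenyl with 3-chlorophenyl on the saturated ring carbon gives a 3.6-fold lower number from compound 1 to compound 3 (0.55 log units; beyond the scatter) in this assay. Within the data shown here, this is the first step here to go beyond the scatter, so the group at this position can shift the number, with compound 3 the more toxic of the pair in this test. No available measurement explains the step. The swap changes both the halogen and where it sits on the phenyl ring, and the compounds shown cannot separate the two. As far as these compounds go, how 3-fluorophenyl, 2-chlorophenyl or an aminophenyl group would behave at this position remains open.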